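The source may hold more compounds than are shown below. What is called first, only, known or untested is meant among the compounds shown, and "the series" means these compounds.

Compound 3 `CC[N+]1(CCCCCCCOc2cc(C)cc(-n3cc(C(=O)Nc4cc(F)cc(F)c4)c(=O)c4ccc(N(C)C)nc43)c2)CCCCC1` gives 67.2% in an assay on LX2 cells for inhibition of COL1A1 promoter (Homo sapiens), read by a luciferase reporter, with a stated time of 24 h, tested at 20 uM (on this read-out lower numbers stand for a weaker effect and higher numbers for a stronger effect at the one concentration tested), the highest of the three numbers measured: compound 1 `Cc1cc(OCCCCCCC[N+]23CCN(CC2)CC3)cc(-n2cc(C(=O)Nc3cc(F)cc(F)c3)c(=O)c3ccc(N(C)C)nc32)c1` gives 10.3% and compound 2 `Cc1cc(OCCCCCCC[N+]2(C)CCCC2)cc(-n2cc(C(=O)Nc3cc(F)cc(F)c3)c(=O)c3ccc(N(C)C)nc32)c1` gives 4.32%, both beyond the scatter below compound 3. Compound 4 `CC[N+]1(CCCCCCCOc2cc(C)cc(-n3cc(C(=O)Nc4cc(F)cc(F)c4)c(=O)c4ccc(N(C)C)nc43)c2)CCCC1` differs from compound 3 by a group of 7 heavy atoms (6 carbon, 1 nitrogen; one five-membered non-aromatic ring with 1 hetero atom) in place of a group of 8 heavy atoms (7 carbon, 1 nitrogen; one six-membered non-aromatic ring with 1 hetero atom), on a saturated chain carbon, seven bonds along the chain from an oxygen on an aromatic ring. The step that bears most directly on this change is a number 62.9 percentage points higher from compound 2 to compound 3 (beyond the scatter), where a six-membered ring with one hetero atom replaced a five-membered one; the move from compound 3 to compound 4 runs the other way, though the ethyl on the nitrogen is kept. The step of a number 6 percentage points lower from compound 1 to compound 2 (within the scatter) also involves a five-membered ring and stayed low. A large fall is therefore expected, a number 42.2 percentage points lower from compound 3 to compound 4 (beyond the scatter), giving compound 4 an estimated 25% with a range from 3% to 60%.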

Compound 4, a percentage reported as inhibition, at one concentration (the size of the read-out at that concentration, not a potency): 35.1%
For compound 4 the middle estimate is 10.1 percentage points below the measured one, and the stated range covers the measured number.
By their numbers in this assay, from the lowest: compounds 2 and 1 (each within the scatter of the next); then compound 4; then compound 3.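

With the ethyl on the ring nitrogen kept, the five-membered ring in place of the six-membered one gives a number 32.1 percentage points lower from compound 3 to compound 4 (beyond the scatter) in this assay, so ring size at this chain end matters on its own. The five-membered ring does not by itself fix the low level: methyl in place of hydrogen on a saturated chain carbon bound to an amine nitrogen in a ring gives a number 30.8 percentage points higher from compound 2 to compound 4 (beyond the scatter), and replacing the two-ring group gives a number 24.8 percentage points higher from compound 1 to compound 4 (beyond the scatter). Nothing shown explains these steps. Going by these compounds, whether a propyl on the ring nitrogen, a seven-membered ring or a morpholine ring at the chain end would raise or lower the number stays open.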